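Swapping piperidinyl for dimethylamino on two related cores

A few compounds are considered here, and "the series" means these few. Any claim that something is new, unique, unknown or untested is made for them only; others in the source may bear on it.

Compound 1 `O=S(=O)(c1ccccc1)n1cc(N2CCCCC2)c2ccccc21` gives 219 nM.
Compound 2 `CN(C)c1cn(S(=O)(=O)c2ccccc2)c2ccccc12` gives 474 nM.
Compound 3 `O=S(=O)(c1ccccc1)n1ccc2c(N3CCCCC3)cccc21` gives 128 nM.

These numbers come from an assay on isolated protein for displacement of a labelled ligand from 5-hydroxytryptamine receptor 6 (Homo sapiens), read by scintillation counting, with a stated time of 1 h; on this read-out higher numbers stand for weaker inhibition and lower numbers for stronger inhibition. Compound 1 and compound 2 share a core and differ by dimethylamino in place of piperidin-1-yl on an aromatic carbon; that change produced a 2.2-fold higher number from compound 1 to compound 2 (0.34 log units; beyond the scatter). Compound 3 has the same atoms as compound 1, joined differently; the difference between the two cores is not broken down here. Compound 4 `CN(C)c1cccc2c1ccn2S(=O)(=O)c1ccccc1` has not yet been measured and differs from compound 3 by dimethylamino in place of piperidin-1-yl on an aromatic carbon. This is the same kind of change as before, but here the group sits on a six-membered aromatic ring of carbon only, ortho to a fused ring and meta to a fused ring, rather than on a five-membered aromatic ring with one nitrogen. Because the earlier change gave a 2.2-fold higher number from compound 1 to compound 2 (0.34 log units; beyond the scatter), for compound 4 a step of similar size is expected, a 2.2-fold higher number from compound 3 to compound 4 (0.34 log units; beyond the scatter). Compound 4 is therefore estimated at 280 nM, between 130 nM and 600 nM.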

Compound 4, inhibition constant: 65 nM
Estimate against measurement, compound 4: 4.3-fold (0.63 log units) above; measured number below the stated range.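

On the core of compound 3, dimethylamino in place of piperidin-1-yl gave a 2.0-fold lower number from compound 3 to compound 4 (0.29 log units; within the scatter), so the loss seen on the core of compound 1 did not carry over. In this assay, the two cores do not respond alike to this change: the same change on two cores in this assay, a 2.2-fold higher number (0.34 log units; beyond the scatter) from compound 1 to compound 2 and a 2.0-fold lower number (0.29 log units; within the scatter) from compound 3 to compound 4, 4.3-fold (0.63 log units) apart, beyond the scatter of two such steps
This does not show why they differ, and the step on the core of compound 3, taken alone, cannot be told apart from no change at all.

Going by these compounds, whether other cyclic amines, such as pyrrolidin-1-yl or morpholin-4-yl, would split the same way on the two cores stays open. So does the behaviour of an open amine with longer chains, such as diethylamino.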